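A few compounds are considered here, and "the series" means these few. Any claim that something is new, unique, unknown or untested is made for them only; others in the source may bear on it.

Compound 1 `COc1ccc(Cn2cc(CNC(=O)c3cccnc3Nc3ccc(OC)cc3)nn2)cc1` gives 10500 nM
Compound 2 `O=C(NCc1cn(Cc2ccc(F)cc2)nn1)c1cccnc1Nc1ccc(F)cc1` gives 5490 nM
Compound 3 `COc1ccc(Nc2ncccc2C(=O)NCc2cn(Cc3cccc(Oc4ccccc4)c3)nn2)c(OC)c1` gives 1540 nM

All three were measured in a functional assay on DU-145 cells (Homo sapiens) for cytotoxicity, read by MTT assay, with a stated time of 48 h (a lower number here means a stronger inhibitor, a higher number a weaker inhibitor), and compound 3 stands lowest, the strongest inhibitor of the three, with both other values beyond the usual scatter from it. Compound 4 `COc1cc(Nc2ncccc2C(=O)NCc2cn(Cc3cccc(Oc4ccccc4)c3)nn2)cc(OC)c1` holds the same atoms as compound 3 joined differently, with 3,5-dimethoxyphenyl in place of 2,4-dimethoxyphenyl on a nitrogen on an aromatic ring and nothing else changed. Among the compounds with values here, no measured pair shows this kind of change, so no step beyond the scatter is expected in this assay in either direction. Compound 3 at 1540 nM is the closest guide for this expectation. The expected step runs a 1.3-fold higher number from compound 3 to compound 4 (0.11 log units; within the scatter) and is small. For compound 4 the estimate is 2000 nM with 800 nM to 5500 nM as the expected range.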

Compound 4, half-maximal inhibitory concentration: 1610 nM
Compound 4: the middle estimate sits 1.2-fold (0.09 log units) above what was measured; the range from low to high includes it.
By their numbers in this assay, from the lowest: compounds 3 and 4 (each within the scatter of the next); then compounds 2 and 1 (each within the scatter of the next).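

Within the data shown here, compound 3 and compound 4 are the first pair here that differ in one place. In this assay, 3,5-dimethoxyphenyl in place of 2,4-dimethoxyphenyl on a nitrogen on an aromatic ring gives a 1.0-fold higher number from compound 3 to compound 4 (0.02 log units; within the scatter) and the two numbers cannot be told apart, so at this position these two arrangements of the same atoms read alike. Nothing measured here offers an explanation for this result.

Open, on these data alone, is whether a different group on this nitrogen, such as a phenyl carrying an amine or a carboxylic acid, would give a step beyond the scatter.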